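The source may report more compounds than this note shows. Statements on the series, on what has been measured and on what is new or still open speak of the compounds shown alone.

Measured in an in vitro assay on Sf21 cells for inhibition of high affinity 3',5'-cyclic-AMP phosphodiesterase 7A (Homo sapiens), read by scintillation proximity assay, with a stated time of 30 min; on this read-out lower numbers stand for stronger inhibition and higher numbers for weaker inhibition:
compound 1 `O=C(Nc1ccccc1)c1cn(Cc2c(F)cccc2F)c2ccc(=O)[nH]c2c1=O` gives 94 nM
compound 2 `CNC(=O)c1ccc(NC(=O)c2cn(Cc3c(F)cccc3F)c3ccc(=O)[nH]c3c2=O)cc1` gives 29 nM
compound 3 `NS(=O)(=O)c1ccc(NC(=O)c2cn(Cc3c(F)cccc3F)c3ccc(=O)[nH]c3c2=O)cc1` gives 34 nM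

Compound 3 stands second highest of the three numbers, within the scatter of its nearest neighbour (a 1.2-fold higher number from compound 2 to compound 3 (0.07 log units; within the scatter)) and clearly apart from compound 1 (a 2.8-fold lower number from compound 1 to compound 3 (0.44 log units; beyond the scatter)). Compound 4 `O=C(Nc1ccc(OC(F)F)cc1)c1cn(Cc2c(F)cccc2F)c2ccc(=O)[nH]c2c1=O` differs from compound 3 by difluoromethoxy in place of sulfamoyl on an aromatic carbon. Within the data shown here, two measured steps bear on this position: a 3.2-fold lower number from compound 1 to compound 2 (0.51 log units; beyond the scatter) and a 2.8-fold lower number from compound 1 to compound 3 (0.44 log units; beyond the scatter), both modest gains on adding a group to the bare ring of compound 1. Difluoromethoxy has not been tested at that place, so its effect is open; compound 4 is expected to land between compound 1 and compound 3, with a 1.6-fold higher number from compound 3 to compound 4 (0.21 log units; within the scatter) estimated. Compound 4 is therefore estimated at 55 nM, within 20 nM to 160 nM.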

Compound 4, half-maximal inhibitory concentration: 71 nM
Compound 4: middle estimate off by 1.3-fold (0.11 log units), on the low side, within the range that was stated.
By their numbers in this assay, from the lowest: compounds 2 and 3 (each within the scatter of the next); then compounds 4 and 1 (each within the scatter of the next).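

Not every group at this place lowers the number: difluoromethoxy in place of hydrogen stays within the scatter (a 1.3-fold lower number from compound 1 to compound 4 (0.12 log units; within the scatter)). Both earlier substituents stand apart from difluoromethoxy, sulfamoyl (a 2.1-fold higher number from compound 3 to compound 4 (0.32 log units; beyond the scatter)) and methylcarbamoyl (a 2.4-fold higher number from compound 2 to compound 4 (0.39 log units; beyond the scatter)), so the gain seen earlier belongs to these two groups rather than to substitution as such. No measurement at hand accounts for this difference.

Going by these compounds, whether an amine, a carboxylic acid or a longer chain would follow sulfamoyl or difluoromethoxy stays open. So does the effect of these groups on any other ring carbon.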